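Moving the Chlorine on the Benzylsulfanyl Arm

The source may report more compounds than this note shows. Statements on the series, on what has been measured and on what is new or still open speak of the compounds shown alone.

Compound 1 `O=C(O)c1ccc(C(=O)/C(=C\c2ccc(F)c([N+](=O)[O-])c2)SCc2ccc(Cl)cc2)cc1` is the starting point of this account. In a physicochemical assay for solubility (on this read-out lower numbers stand for lower solubility and higher numbers for higher solubility), compound 1 gives < 1000 ug/mL, which is a limit of the assay rather than a measured number. Compound 2 `O=C(/C(=C\c1ccc(F)c([N+](=O)[O-])c1)SCc1ccc(F)cc1)c1ccc(F)cc1` gives < 1000 ug/mL in this assay, again only a limit. Compound 3 `O=C(O)c1ccc(C(=O)/C(=C\c2ccc(Cl)c([N+](=O)[O-])c2)SCc2ccc(Cl)cc2)cc1` gives < 1000 ug/mL in this assay, also a limit. Among the measured compounds shown here, the single step between measured compounds that differ in one place, a step that the two limits leave unreadable from compound 1 to compound 3, cannot be read because of the limit of < 1000 ug/mL in this assay, at which 3 of the 3 values shown sit, so no measured step in this set has a readable size.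

Compound 4 `O=C(O)c1ccc(C(=O)/C(=C\c2ccc(F)c([N+](=O)[O-])c2)SCc2ccccc2Cl)cc1` differs from compound 1 in one place: 2-chlorophenyl in place of 4-chlorophenyl on a saturated chain carbon bound to a sulfur. For the measured compounds named here, no measured step touches this kind of change, and the one step recorded, from compound 1 to compound 3, is unreadable, so the data give no size or direction for it beyond the scatter. Going by the values given here, what the three values do show is that every compound measured so far sits at the same limit of this assay. The account therefore expects compound 4 to remain in the same region, with an expected step that the limit leaves unreadable from compound 1 to compound 4 that is most likely to appear as no readable change. The estimate for compound 4 is 200 ug/mL, with a range from 20 ug/mL to 1000 ug/mL.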

Compound 4, solubility: < 1000 ug/mL
Compound 4 gave a limit, no number; the forecaster's own chance of this, stated with the estimate: 85%; the middle value lies beyond the limit too.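

In this assay no step can be read between compound 1 and compound 4, because each gives only a limit and no number: the limit of < 1000 ug/mL in this assay, at which 4 of the 4 values shown sit. The compounds shown leave open how far the solubility of any of them lies under that limit, and whether 2-chlorophenyl in place of 4-chlorophenyl changes it at all.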